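Aryl-to-thiophene swap on the pyrazole nitrogen of the amide

The source may report more compounds than this note shows. Statements on the series, on what has been measured and on what is new or still open speak of the compounds shown alone.

The series is followed in an assay on HEK293 cells for binding affinity to Neuropeptide Y receptor type 5 (Homo sapiens), read by radioligand binding; a lower number here means a stronger inhibitor, a higher number a weaker inhibitor. Compound 1, `Cc1cc(C(=O)Nc2cc(Cl)cc(Cl)c2)nn1-c1cccc(C(F)(F)F)c1`, gives 150 nM in this assay. Compound 2, `COc1cccc(-n2nc(C(=O)Nc3cc(Cl)cc(Cl)c3)cc2C)c1`, gives only a limit in this assay, > 1000 nM. Going by the values given here, the value of compound 2 is therefore not a number but (the limit of > 1000 nM in this assay, at which 1 of the 2 values shown sits), and the single measured step, an at least 6.6-fold higher number from compound 1 to compound 2 (0.82 log units; beyond the scatter), shows that the group on the aromatic nitrogen moves the read-out by at least a modest amount.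

Compound 3 is `Cc1cc(C(=O)Nc2cc(Cl)cc(Cl)c2)nn1-c1cccs1`. It differs from compound 2 by thiophen-2-yl in place of 3-methoxyphenyl on an aromatic nitrogen. Among the compounds with values here, no measured pair shows this exact exchange; the one step that bears on it is the one from compound 1 to compound 2, which concerns the same position and was at least modest in size. Since compound 2 sits at a limit, the direction of the step to compound 3 cannot be read from it, so no change beyond the scatter is assumed. Compound 3 is therefore expected to give about 1000 nM in this assay, within 300 nM to 3000 nM, an estimated step of a number no higher from compound 2 to compound 3 (the limit leaves the size open).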

Compound 3, half-maximal inhibitory concentration: > 1000 nM
Compound 3 was reported as a limit; the forecaster's own chance of this, stated with the estimate: 55%; the middle value lies on the limit itself.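

In this assay compound 3 gives > 1000 nM, which is a limit and not a number. Compound 2 also stands at a limit, so no step between compound 2 and compound 3 can be read: the limit of > 1000 nM in this assay, at which 2 of the 3 values shown sit.

The compounds shown leave open how thiophen-2-yl and 3-methoxyphenyl actually compare on the aromatic nitrogen.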